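The compounds below may be only part of what the source reports. "The series", "measured", "known", "first", "only" and "open" are said of these compounds alone.

Compound 1 `O=S(=O)(NCCNC(=S)Nc1ccc(Cl)cc1)c1ccc(-c2ccccc2OCc2ccccc2)s1` was studied in a functional assay on RS4-11 cells (Homo sapiens) for inhibition, read by CCK-8 assay, with a stated time of 48 h; a higher number here means a weaker inhibitor, a lower number a stronger inhibitor. For compound 1 this assay gives no number but only a limit, > 50000 nM. The same holds for compound 2 `COc1ccc(Oc2ccccc2-c2ccsc2S(=O)(=O)N2CCN(C(=S)Nc3ccc([N+](=O)[O-])cc3)CC2)cc1OC`, which in this assay also reaches only a limit, > 50000 nM. So compound 1 stands at the edge of what the assay can report, together with the one other measured compound, since (the limit of > 50000 nM in this assay, at which 2 of the 2 values shown sit); nothing in these two values separates them.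

Compound 3 `COc1cccc(NC(=O)NCCNS(=O)(=O)c2ccc(-c3ccccc3OCc3ccccc3)s2)c1` differs from compound 1 in a single place: a group of 11 heavy atoms (8 carbon, 1 nitrogen, 2 oxygen; one six-membered aromatic ring of carbon only) in place of a group of 10 heavy atoms (7 carbon, 1 nitrogen, 1 sulfur, 1 chlorine; one six-membered aromatic ring of carbon only), on an amine nitrogen. Within the data shown here, no step between two measured compounds is available to guide a prediction, so the change is expected to move the value little, if at all, beyond the usual scatter, and compound 3 is expected to stay at the limit as well. Compound 3 is thus estimated at about 60000 nM, with a range from 20000 nM to 200000 nM. This estimate corresponds to an expected step that the limit leaves unreadable from compound 1 to compound 3.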

Compound 3, half-maximal inhibitory concentration: > 20000 nM
Compound 3 gave a limit, no number; the forecaster's own chance of this, stated with the estimate: 80%; the middle value is on the limit's open side.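

Compound 1 and compound 3 each end at a limit and not at a number, so no step can be read between them. The compounds shown leave open whether the (3-methoxyphenyl)carbamoyl group on the amine nitrogen changes inhibition at all in this assay.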